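Removing a methoxy from the pendant phenyl ring

This account rests on a few compounds, and the source may have more. Where it says the series, first, only, none or still open, it means among the compounds named here.

Measured compounds:
Compound 1 `COc1ccc(-c2[nH]c3ccccc3c2/C=C(\C#N)S(=O)(=O)c2ccccc2)cc1` gives 450 nM in a functional assay on DU-145 cells (Homo sapiens) for inhibition, read by sulforhodamine B assay, with a stated time of 48 h; a lower number here means a stronger inhibitor of growth, a higher number a weaker inhibitor of growth.
Compound 2 `COc1ccc(-c2[nH]c3ccc(OC)cc3c2/C=C(\C#N)S(=O)(=O)c2ccccc2)cc1` gives 875 nM in this assay.
Compound 3 `COc1ccc(-c2[nH]c3ccc(OC)cc3c2C=C(C#N)C#N)cc1` gives 917 nM in this assay.

Compound 1 carries the smallest number of the three; its gap to compound 2 lies within the scatter, its gap to compound 3 just beyond it. Compound 4 `N#C/C(=C\c1c(-c2ccccc2)[nH]c2ccccc12)S(=O)(=O)c1ccccc1` differs from compound 1 by hydrogen in place of methoxy on an aromatic carbon. Among the compounds with values here, the one measured step in this set that changes a methoxy, a 1.9-fold higher number from compound 1 to compound 2 (0.29 log units; within the scatter), adds that group on a different ring rather than removing it from the 4-methoxyphenyl, and its size stays within the scatter. Within the data shown here, no measured pair tests the 4-methoxyphenyl to phenyl change itself, so the expectation rests on that single neighbouring step. The estimate is a step from compound 1 to compound 4 of a 1.3-fold higher number from compound 1 to compound 4 (0.12 log units; within the scatter), that is, no change beyond the scatter, with a wide range to allow for the untested position. Compound 4 is therefore expected to give about 600 nM in this assay, between 250 nM and 1500 nM.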

Compound 4, concentration for 50% growth inhibition: 2900 nM
Estimate against measurement, compound 4: 4.8-fold (0.68 log units) below; the measured number lies above the stated range.
By their numbers in this assay, from the lowest: compounds 1, 2 and 3 (each within the scatter of the next, the first and the last beyond it); then compound 4.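

Within the data shown here, removing the methoxy from the 4-methoxyphenyl group in this assay gives a 6.4-fold higher number from compound 1 to compound 4 (0.81 log units; beyond the scatter), the only step between compounds differing in one place here that lies beyond the scatter. Adding a methoxy on a different ring gave a 1.9-fold higher number from compound 1 to compound 2 (0.29 log units; within the scatter), which stays within the scatter, so in this small set a methoxy change matters at this position but not measurably at the other. Nothing measured here accounts for the loss of growth inhibition when hydrogen replaces the methoxy.

With only methoxy and hydrogen shown at this position, it remains open whether a hydroxyl, an ethoxy group, a fluorine or an amine would keep the number near that of compound 1. As far as these compounds go, it is also open whether the same change would have a similar effect in compound 2 or compound 3, which carry a second methoxy.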